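Swapping the amine chain of compound 3 for chloro

This account rests on a few compounds, and the source may have more. Where it says the series, first, only, none or still open, it means among the compounds named here.

Compound 3 `C=CCOc1ccc2c(NCCN(C)C)ccnc2c1` carries a (2-(dimethylamino)ethyl)amino group and an allyl ether; in a functional assay on DLD-1 cells (Homo sapiens) for cytotoxicity, read by MTT assay, with a stated time of 48 h (on this read-out lower numbers stand for stronger inhibition and higher numbers for weaker inhibition), compound 3 gives 1530 nM, the second highest of the three numbers here. Among the measured compounds shown here, compound 1 `CN(C)CCNc1ccnc2cc(OCc3ccc(F)cc3)ccc12` gives 810 nM, and the only measured step, a 1.9-fold higher number from compound 1 to compound 3 (0.28 log units; within the scatter), concerns the ether side and leaves the amine untouched. Compound 2 `CCCCOc1ccc2c(Cl)ccnc2c1`, which bears chloro in place of that amine on a butyl ether, gives 3780 nM, the highest number of the three. Compound 4 `C=CCOc1ccc2c(Cl)ccnc2c1` makes the change (chloro in place of (2-(dimethylamino)ethyl)amino on an aromatic carbon). For the measured compounds named here, no measured step isolates this swap, but the value of compound 2 points to a higher number. Compound 4 is therefore expected to give 4000 nM, with a range from 1500 nM to 12000 nM, an expected step of a 2.6-fold higher number from compound 3 to compound 4 (0.42 log units; beyond the scatter).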

Compound 4, half-maximal inhibitory concentration: 2890 nM
Compound 4: middle estimate off by 1.4-fold (0.14 log units), on the high side; measured number inside the range.
By their numbers in this assay, from the lowest: compounds 1, 3, 4 and 2 (each within the scatter of the next, the first and the last beyond it).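

On the aromatic carbon opposite the ring nitrogen, chloro in place of (2-(dimethylamino)ethyl)amino gives a 1.9-fold higher number from compound 3 to compound 4 (0.28 log units; within the scatter), so this swap, the first measured at this place, stays within the scatter despite removing the whole amine chain. With chloro in place, the ether side also stays within the scatter, with vinyl in place of propyl giving a 1.3-fold lower number from compound 2 to compound 4 (0.12 log units; within the scatter) in this pair. Nothing measured here explains either result. Going by these compounds, whether a longer amine chain or a carboxylic acid on this carbon would move the number beyond the scatter remains open. So does how chloro behaves alongside the 4-fluorophenyl ether of compound 1.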